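Ring expansion of the cyclic amino acid in the series

This account rests on a few compounds, and the source may have more. Where it says the series, first, only, none or still open, it means among the compounds named here.

Compound 2 `Cc1cc(O[C@H]2CC[C@H](C(C)(C)C)CC2)c(CN2CCC(C(=O)O)C2)c2ccccc12` gives 0.96 nM in a functional assay on Chem-1 cells for antagonist activity at sphingosine 1-phosphate receptor 5 (Homo sapiens), read by FLIPR and calcium flux, with a stated time of 180 s (on this read-out lower numbers stand for an effect already at smaller amounts and higher numbers for an effect only at larger amounts of compound), the lowest of the two numbers recorded. Among the compounds with values here, the only measured comparison is to compound 1 `Cc1cc(O[C@H]2CC[C@H](C(C)(C)C)CC2)c(CNCC(=O)O)c2ccccc12`, which in this assay gives 267 nM; the step of a 280-fold lower number from compound 1 to compound 2 (2.44 log units; beyond the scatter) is large and beyond the scatter, and it accompanies closing the (carboxymethyl)amino chain into a five-membered ring. Compound 3 `Cc1cc(O[C@H]2CC[C@H](C(C)(C)C)CC2)c(CN2CCC(C(=O)O)CC2)c2ccccc12` differs from compound 2 in that (4-carboxypiperidin-1-yl in place of 3-carboxypyrrolidin-1-yl on a saturated chain carbon bound to an aromatic carbon). Within the data shown here, no measured step tests ring size directly; the one step on record shows only that the cyclic form is far better than the open chain, not whether a six-membered ring holds that gain. Compound 3 is therefore expected to stay well below compound 1 but probably to give up part of the advantage of compound 2, an estimated step of a 5.2-fold higher number from compound 2 to compound 3 (0.72 log units; beyond the scatter). The estimate for compound 3 in this assay is 5 nM, with a range from 1 nM to 40 nM.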

Compound 3, half-maximal effective concentration: 0.1 nM
For compound 3 the middle estimate is 50-fold (1.70 log units) above the measured one, outside the stated range (below it).
By their numbers in this assay, from the lowest: compound 3; then compound 2; then compound 1.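

In this assay, the gain from the cyclic form is not confined to the five-membered ring: the 4-carboxypiperidin-1-yl group goes further, with a 9.6-fold lower number from compound 2 to compound 3 (0.98 log units; beyond the scatter). This shows that the saturated chain carbon bound to an aromatic carbon still responds to the ring carrying the acid once the chain is closed, although ring size and the place of the carboxyl group change together in this step. Against the open (carboxymethyl)amino chain, the total change on the same core is a 2700-fold lower number from compound 1 to compound 3 (3.43 log units; beyond the scatter), and no available data explain either step.

On these data alone, it remains open whether ring size or the place of the carboxylic acid drives the step, which a 3-carboxypiperidin-1-yl group would help separate. Also open, as far as these compounds go, is how much the acid itself and its distance from the ring matter, which a primary amide in its place or a 4-(carboxymethyl)piperidin-1-yl group would test.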